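This account rests on a few compounds, and the source may have more. Where it says the series, first, only, none or still open, it means among the compounds named here.

Compound 1 `C/C(=N\NC(=O)/C(C#N)=C/c1ccc(Br)cc1)c1c(O)c2ccc(O)cc2oc1=O`: 10600 nM
Compound 2 `C/C(=N\NC(=O)/C(C#N)=C/c1ccc([N+](=O)[O-])cc1)c1c(O)c2ccc(O)cc2oc1=O`: 8360 nM

In a functional assay on HeLa cells (Homo sapiens) for cytotoxicity, read by MTT assay, with a stated time of 24 h (a lower number here means a stronger inhibitor, a higher number a weaker inhibitor), compound 2 gives 8360 nM and compound 1 gives 10600 nM, so the two sit within the scatter of each other. Only these two numbers are available so far. The next compound is compound 3 `C/C(=N\NC(=O)/C(C#N)=C/c1cccc(Br)c1)c1c(O)c2ccc(O)cc2oc1=O`. Its change from compound 2 is 3-bromophenyl in place of 4-nitrophenyl on a double-bonded chain carbon bound to a double-bonded chain carbon. Among the compounds with values here, the one measured step that bears on this is a 1.3-fold lower number from compound 1 to compound 2 (0.10 log units; within the scatter), nitro in place of bromo on an aromatic carbon. Within the data shown here, compound 3 also carries a bromo group, but at a different place on the ring from compound 1, and no measured step shows what that difference does. The expected change is therefore small, with nothing beyond the scatter: a 1.1-fold higher number from compound 2 to compound 3 (0.06 log units; within the scatter) is the estimated step. For compound 3 the estimate in this assay is 9500 nM, with an expected range of 4500 nM to 20000 nM.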

Compound 3, half-maximal inhibitory concentration: 24300 nM
Compound 3: the middle estimate sits 2.6-fold (0.41 log units) below what was measured, outside the stated range (above it).
By their numbers in this assay, from the lowest: compounds 2 and 1 (each within the scatter of the next); then compound 3.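

With the bromo group kept and only its place on the ring changed, 3-bromophenyl in place of 4-bromophenyl gives a step beyond the scatter in this assay (a 2.3-fold higher number from compound 1 to compound 3 (0.36 log units; beyond the scatter)), whereas the earlier swap of bromo for nitro did not. Replacing 4-nitrophenyl with 3-bromophenyl gives a step of similar modest size (a 2.9-fold higher number from compound 2 to compound 3 (0.46 log units; beyond the scatter)), which makes compound 3 the weakest of the three in this cell assay. So at this chain carbon, where a substituent sits on the phenyl ring matters more here than whether it is bromo or nitro, and nothing measured here explains the shift.

On these data alone, it remains open whether a nitro group would respond to a change of ring place as bromo does. Also unknown is how an amine or a carboxylic acid on the phenyl ring would compare with bromo.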